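Aryl swap on the ring nitrogen of the shared core

The source may report more compounds than this note shows. Statements on the series, on what has been measured and on what is new or still open speak of the compounds shown alone.

Compound 1 `C[C@H](Nc1ncnc2[nH]cnc12)c1nn(-c2cccnc2)c2cc(F)ccc12` stands lowest of the three numbers in a functional assay on Bel-7402 cells (Homo sapiens) for inhibition, read by sulforhodamine B assay, with a stated time of 72 h, tested at 10 uM (on this read-out lower numbers stand for less inhibition and higher numbers for more inhibition at the one concentration tested (going by the name of the read-out)), where compound 1 gives 8%. Within the data shown here, compound 2 `C[C@H](Nc1ncnc2[nH]cnc12)c1nn(-c2cccnc2)c2cc(Cl)ccc12` gives 17%, and the only single-point step known, a number 9 percentage points higher from compound 1 to compound 2 (within the scatter), lies within the scatter. Compound 3 `C[C@H](Nc1nc(N)nc(N)c1C#N)c1nn(-c2cccnc2)c2cc(C(F)(F)F)ccc12` gives 60%, but it differs from compound 1 in more than one place, so its number cannot be read as a step for any one change. Compound 4 `C[C@H](Nc1ncnc2[nH]cnc12)c1nn(-c2cccc(F)c2)c2cc(F)ccc12` differs from compound 1 by 3-fluorophenyl in place of pyridin-3-yl on an aromatic nitrogen. Among the measured compounds shown here, no measured step touches this position, and the one step that is known is flat, so no shift beyond the scatter is expected for a number 4 percentage points higher from compound 1 to compound 4 (within the scatter). Compound 4 is therefore expected at 12%, with a range from 0% to 30%.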

Compound 4, a percentage reported as inhibition, at one concentration (the size of the read-out at that concentration, not a potency): -17%
For compound 4 the middle estimate is 29 percentage points above the measured one, outside the stated range (below it).
By their numbers in this assay, from the lowest: compound 4; then compounds 1 and 2 (each within the scatter of the next); then compound 3.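

Unlike the flat chloro-for-fluoro step, the aryl group on the aromatic nitrogen gives a single change that moves the number beyond the scatter in this assay: 3-fluorophenyl in place of pyridin-3-yl gives a number 25 percentage points lower from compound 1 to compound 4 (beyond the scatter). So this position is not silent in the series, and the change lowers the read-out. No measurement on hand bears on the reason for this step.

The swap changes the ring nitrogen and the fluorine together, and unsubstituted phenyl would separate the two. Going by these compounds, whether an amine on the pyridin-3-yl ring, or the same swap on compound 2, follows this direction remains open.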